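A few compounds are considered here, and "the series" means these few. Any claim that something is new, unique, unknown or untested is made for them only; others in the source may bear on it.

In an ADME assay on PBMC cells (Homo sapiens) for cytotoxicity, with a stated time of 5 days (on this read-out lower numbers stand for stronger inhibition and higher numbers for weaker inhibition), compound 1 `O=C(/C=C/c1ccc(N2CCCCC2)cc1)c1ccc(I)s1` gives only a limit, > 100000 nM. Compound 2 `c1csc(C2=NNC(c3ccc(N4CCCCC4)cc3)C2)c1` gives 20800 nM. Compound 3 `c1cc(C2=NNC(c3ccc(N4CCCCC4)cc3)C2)cs1` likewise gives only a limit, > 100000 nM. Compound 3 therefore sits with compound 1 at the limit of > 100000 nM in this assay, at which 2 of the 3 values shown sit, and compound 2 alone shows a number. Going by the values given here, the single measured step, an at least 4.8-fold higher number from compound 2 to compound 3 (0.68 log units; beyond the scatter), ran up to that limit. Compound 4 `Cc1ccsc1C1=NNC(c2ccc(N3CCCCC3)cc2)C1` carries 3-methylthiophen-2-yl in place of thiophen-3-yl on a carbon with a double bond to nitrogen; this change restores the thiophen-2-yl pattern of compound 2 and adds a methyl. Among the compounds with values here, the step of an at least 4.8-fold higher number from compound 2 to compound 3 (0.68 log units; beyond the scatter) is the only guide, so its reversal is expected to bring the number back down, while the methyl has no precedent here. For compound 4 an estimate of 30000 nM is made, with a range from 10000 nM to 100000 nM, meaning an expected step of an at least 3.3-fold lower number from compound 3 to compound 4 (0.52 log units; beyond the scatter).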

Compound 4, half-maximal inhibitory concentration: 11000 nM
For compound 4 the middle estimate is 2.7-fold (0.44 log units) above the measured one, and the stated range covers the measured number.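

Replacing thiophen-3-yl with 3-methylthiophen-2-yl gives an at least 9.0-fold lower number from compound 3 to compound 4 (0.95 log units; beyond the scatter), so a measured number returns with this group on the carbon with a double bond to nitrogen. Methyl in place of hydrogen on an aromatic carbon gives a 1.9-fold lower number from compound 2 to compound 4 (0.28 log units; within the scatter), so the methyl does not separate the pair. The larger step has only a lower bound, as compound 3 is a limit and not a number: the limit of > 100000 nM in this assay, at which 2 of the 4 values shown sit.

The compounds shown leave open whether a methyl on thiophen-3-yl would also yield a measured number. Also open, as far as these compounds go, is how an ethyl or a carboxylic acid in the methyl's place would read.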